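The source may report more compounds than this note shows. Statements on the series, on what has been measured and on what is new or still open speak of the compounds shown alone.

Measured in a functional assay on HepG2 cells (Homo sapiens) for cytotoxicity; a lower number here means that less compound is tolerated, a higher number that more compound is tolerated:
Compound 1 `O=c1ccn(COC(CO)CO)c(=O)[nH]1`: > 462000 nM
Compound 2 `COc1nc(=O)n(COC(CO)CO)cc1Br`: > 323000 nM
Compound 3 `Cc1cc(=O)[nH]c(=O)n1COC(CO)CO`: > 434000 nM

Each of these three values is a limit of this assay rather than a measured number. For compound 3 the value is therefore only a limit, and the two companion values are limits as well, so compound 3 cannot be placed above or below them. Among the compounds with values here, the one measured step that involves compound 3, a step that the two limits leave unreadable from compound 1 to compound 3, is itself unreadable. Compound 4 `Cc1c(I)c(=O)[nH]c(=O)n1COC(CO)CO` differs from compound 3 by iodo in place of hydrogen on an aromatic carbon. Within the data shown here, no measured step tells how such a change moves this assay, so no shift beyond the scatter is expected, and compound 4 is expected to return a limit too. The estimate for compound 4 is 400000 nM, between 100000 nM and 1000000 nM, which corresponds to an expected step of an at least 1.0-fold lower number from compound 3 to compound 4 (0.03 log units; that floor lies within the scatter).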

Compound 4, half-maximal cytotoxic concentration: > 280000 nM
Compound 4 ended at the assay's limit (the forecaster's own chance of this, stated with the estimate: 85%); the middle value is on the limit's open side.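

Compound 3 and compound 4 both ended at limits of the assay rather than measured numbers, so the step between them cannot be read. The compounds shown leave open whether iodo in place of hydrogen on an aromatic carbon shifts the result in this assay at all.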